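The source may hold more compounds than are shown below. What is called first, only, known or untested is meant among the compounds shown, and "the series" means these compounds.

Measured so far:
- compound 1 `CCC(=O)N1CCN(c2nc(-c3cnn(C)c3)ncc2C#N)C[C@H]1C`: < 36 mL/min/kg
- compound 2 `C[C@@H]1CN(c2ncc(C#N)c(-c3cnn(C)c3)n2)CCN1C(=O)C1CC1`: 39 mL/min/kg
- compound 3 `C[C@@H]1CN(c2cnc(C#N)c(-c3cnn(C)c3)n2)CCN1C(=O)C1CC1`: < 36 mL/min/kg

In an ADME assay on microsomes from liver (Rattus norvegicus) for pharmacokinetics (a lower number here means slower removal, a higher number faster removal of the compound), compound 1 gives < 36 mL/min/kg, which is a limit of the assay rather than a number. Compound 3 likewise gives < 36 mL/min/kg, also a limit. Compound 2 gives 39 mL/min/kg, a value that sits close to where the other two compounds lie, so the three measured compounds cannot be ordered against each other. Compound 1 therefore stands at the limit of < 36 mL/min/kg in this assay, at which 2 of the 3 values shown sit, the slow-removal end of what has been measured.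

Compound 4 `C[C@@H]1CN(c2nc(-c3cnn(C)c3)ncc2C#N)CCN1C(=O)C1CCC1` differs from compound 1 by cyclobutyl in place of ethyl on a carbonyl carbon. Among the measured compounds shown here, no measured pair isolates this change, so the expectation rests only on the level at which compound 1 and its two neighbours sit. The step is expected to be small, if anything toward faster removal, and not beyond the scatter; this estimate means a step of an at least 1.1-fold higher number from compound 1 to compound 4 (0.06 log units; that floor lies within the scatter). Compound 4 is expected to show 42 mL/min/kg in this assay, with a range from 25 mL/min/kg to 75 mL/min/kg.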

Compound 4, clearance in the Rattus norvegicus assay: < 36 mL/min/kg
Compound 4: a limit, no number (the forecaster's own chance of this, stated with the estimate: 35%); at least 1.1-fold (0.06 log units) between middle value and limit.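

Among the compounds shown here, in the Rattus norvegicus assay compound 1 and compound 4 both stand at a limit of the assay, so no step between them can be read. In a physicochemical assay for lipophilicity, read by HPLC (on this read-out lower numbers stand for lower lipophilicity and higher numbers for higher lipophilicity), compound 1 gives 1.4 and compound 4 gives 2. As far as these compounds go, whether cyclobutyl in place of ethyl on a carbonyl carbon shifts the read-out in the Rattus norvegicus assay stays open.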